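The source may hold more compounds than are shown below. What is called first, only, known or untested is meant among the compounds shown, and "the series" means these compounds.

Measured so far in an ADME assay on microsomes from liver (Homo sapiens) for metabolic stability, read by LC-MS, with a stated time of 10 min; on this read-out higher numbers stand for a more stable compound and lower numbers for a less stable compound:
- compound 1, `CN(C[C@H]1Cc2c(cccc2N2CCN(C3CC3)CC2)CN1)[C@H]1CCCc2cccnc21`: 15.5%
- compound 2, `CN(C[C@H]1Cc2c(cccc2N2CCNCC2)CN1)[C@H]1CCCc2cccnc21`: 99.7%
- compound 3, `CC(C)N1CCN(c2cccc3c2C[C@H](CN(C)[C@H]2CCCc4cccnc42)NC3)CC1`: 56.6%

Compound 3 holds the second highest of the three numbers in this assay. Its nearest neighbour is compound 1 a number 41.1 percentage points higher from compound 1 to compound 3 (beyond the scatter); the furthest is compound 2 a number 43.1 percentage points lower from compound 2 to compound 3 (beyond the scatter). The third pair is a number 84.2 percentage points higher from compound 1 to compound 2 (beyond the scatter), so every change made so far at the amine nitrogen of this ring has moved the read-out well beyond the scatter, in both directions.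

Compound 4, `C[C@@H]1CN(c2cccc3c2C[C@H](CN(C)[C@H]2CCCc4cccnc42)NC3)C[C@H](C)N1C`, has not yet been measured in this assay. It differs from compound 3 as follows: 3,4,5-trimethylpiperazin-1-yl in place of 4-isopropylpiperazin-1-yl on an aromatic carbon. The three steps above all concern the same piperazine position, and all were large; none of them involves the group that enters here, so the direction cannot be read from them, only the likelihood of a sizeable move. Compound 4 is expected to give 50% in this assay, within 15% to 90%. The estimate implies a step of a number 6.6 percentage points lower from compound 3 to compound 4 (within the scatter) from compound 3, with wide uncertainty because of the size of a number 43.1 percentage points lower from compound 2 to compound 3 (beyond the scatter) and a number 41.1 percentage points higher from compound 1 to compound 3 (beyond the scatter).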

Compound 4, percent of the compound remaining: 24.6%
Beside the measured number, compound 4's estimate is 25.4 percentage points above it; low and high end bracket the measured number.
By their numbers in this assay, from the lowest: compounds 1 and 4 (each within the scatter of the next); then compound 3; then compound 2.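

In this assay, the exchange of 4-isopropylpiperazin-1-yl for 3,4,5-trimethylpiperazin-1-yl, two groups of the same atoms joined differently, gives a number 32 percentage points lower from compound 3 to compound 4 (beyond the scatter), so the arrangement of carbon on the piperazine matters at this position, and not only the presence of a substituent on the ring nitrogen. Set against the unsubstituted ring, the same group gives a number 75.1 percentage points lower from compound 2 to compound 4 (beyond the scatter), and set against 4-cyclopropylpiperazin-1-yl it gives a number 9.1 percentage points higher from compound 1 to compound 4 (within the scatter), which leaves the piperazin-1-yl of compound 2 clear of all three substituted piperazines shown. No measured evidence is available that bears on these differences.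

From the compounds shown here alone, how 4-methylpiperazin-1-yl or 3,5-dimethylpiperazin-1-yl would read stays open, and with it the share of each methyl group in the step. Also open, going by these compounds, is whether an acetyl group or a hydroxyethyl chain on the ring nitrogen would read nearer compound 2 or compound 4.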